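Propyl against ethyl on the shared core

The source may report more compounds than this note shows. Statements on the series, on what has been measured and on what is new or still open speak of the compounds shown alone.

Measured so far:
compound 1 `CCCc1cc2ccccc2nc1-c1cc(-c2ccc(F)cc2)no1` — in a functional assay on COLO 205 cells (Homo sapiens) for inhibition, read by MTT assay, with a stated time of 24 h (a lower number here means a stronger inhibitor, a higher number a weaker inhibitor), compound 1 gives 50300 nM
compound 2 `CCc1cc2ccccc2nc1-c1cc(-c2ccc(C)cc2)no1` — in this assay compound 2 gives > 100000 nM, which is a limit of the assay and not a number

Compound 2 stands at the limit of > 100000 nM in this assay, at which 1 of the 2 values shown sits; its place relative to compound 1 cannot be fixed from the numbers shown. Compound 3 `CCCc1cc2ccccc2nc1-c1cc(-c2ccc(C)cc2)no1` carries methyl in place of hydrogen on a saturated chain carbon, two bonds along the chain from an aromatic carbon, that is methyl in place of hydrogen on a saturated chain carbon, two bonds along the chain from an aromatic carbon, so ethyl becomes propyl. Going by the values given here, no step between measured compounds is available to calibrate this change. Compound 1, which also bears a propyl chain, gives a measured number in this assay rather than a limit. The expected step of an at least 1.4-fold lower number from compound 2 to compound 3 (0.15 log units; that floor lies within the scatter) is small, at most towards stronger inhibition, and likely within the scatter. Compound 3 is estimated at 70000 nM, between 25000 nM and 200000 nM.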

Compound 3, half-maximal inhibitory concentration: > 100000 nM
Compound 3 was reported as a limit (the forecaster's own chance of this, stated with the estimate: 45%); at least 1.4-fold (0.15 log units) between middle value and limit.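

In this assay compound 3 gives > 100000 nM, which is a limit of the assay and not a number. With propyl held constant, methyl in place of fluoro on an aromatic carbon now has a readable step, an at least 1.9-fold higher number from compound 1 to compound 3 (0.29 log units; that floor lies within the scatter), but the floor of that step lies within the scatter, so this pair alone does not establish a real difference. The ethyl to propyl step cannot be read, and the limit is now shared by two compounds: the limit of > 100000 nM in this assay, at which 2 of the 3 values shown sit.

Still open, as far as these compounds go, is whether methyl to ethyl or ethyl to propyl changes the number at all on a compound that gives a measured value. Also open, from the compounds shown here alone, is whether a butyl chain, or an amine in place of the methyl, would give a number in this assay.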